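Swapping the sultam for a lactam on the piperidine

A few compounds are considered here, and "the series" means these few. Any claim that something is new, unique, unknown or untested is made for them only; others in the source may bear on it.

Of the compounds shown here, three have been measured in an assay on CHO-K1 cells for displacement of a labelled ligand from melanin-concentrating hormone receptor 1 (Homo sapiens), read by scintillation proximity assay, with a stated time of 2 h; on this read-out lower numbers stand for stronger inhibition and higher numbers for weaker inhibition. Compound 1 `Cc1nc(N2CCC(O)CC2)nc2ccc(NC(=O)/C=C/c3ccc(Cl)cc3)cc12` gives 107 nM, and compound 3 `C/C(=C\C(=O)Nc1ccc2nc(N3CCC(N4CCCC4=O)CC3)nc(C)c2c1)c1ccc(OC(F)(F)F)cc1` gives 69 nM. Compound 2 `Cc1nc(N2CCC(N3CCCS3(=O)=O)CC2)nc2ccc(NC(=O)/C=C/c3ccc(OC(F)(F)F)cc3)cc12` gives 4 nM, the lowest of the three numbers, with compound 3 nearest and compound 1 furthest, both beyond the scatter. Compound 4 `Cc1nc(N2CCC(N3CCCC3=O)CC2)nc2ccc(NC(=O)/C=C/c3ccc(OC(F)(F)F)cc3)cc12` has not been measured; it differs from compound 2 in one place: a group of 6 heavy atoms (4 carbon, 1 nitrogen, 1 oxygen; one five-membered non-aromatic ring with 1 hetero atom) in place of a group of 7 heavy atoms (3 carbon, 1 nitrogen, 2 oxygen, 1 sulfur; one five-membered non-aromatic ring with 2 hetero atoms), on a saturated ring carbon. For the measured compounds named here, no measured pair isolates this change. The account expects a modest step toward a higher number, a 3.0-fold higher number from compound 2 to compound 4 (0.48 log units; beyond the scatter), beyond the scatter but small. Compound 4 is estimated at 12 nM in this assay, within a range from 4 nM to 40 nM.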

Compound 4, half-maximal inhibitory concentration: 11 nM
Beside the measured number, compound 4's estimate is 1.1-fold (0.04 log units) above it, within the range that was stated.
By their numbers in this assay, from the lowest: compound 2; then compound 4; then compounds 3 and 1 (each within the scatter of the next).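

In this assay, for the compounds shown here, replacing the sultam with 2-oxopyrrolidin-1-yl on the saturated ring carbon gives a 2.8-fold higher number from compound 2 to compound 4 (0.44 log units; beyond the scatter) as the first measured step at this position. The lactam keeps compound 4 at 11 nM, so the sulfur-containing ring is not required for a low number, although compound 2 remains lower by a modest margin beyond the scatter. No measurement shown gives a reason for this step.

The compounds shown leave open how a six-membered lactam, an amine or a carboxylic acid would read on this carbon. They also leave open whether the step would hold with a different group on the rest of the molecule.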